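Chlorophenyl for Isobutyl in a Bombesin Receptor Agonist Series

The source may report more compounds than this note shows. Statements on the series, on what has been measured and on what is new or still open speak of the compounds shown alone.

Measured compounds:
compound 1 `O=C(O)c1ccccc1-c1ccc(CCc2ncc(CC3CCCC3)[nH]2)cc1`: 7.9 nM
compound 2 `O=C(O)c1ccccc1-c1ccc(CCc2ncc(Cc3ccccc3Cl)[nH]2)cc1`: 22 nM
compound 3 `CC(C)CCc1cnc(CCc2ccc(-c3ccccc3C(=O)O)cc2)[nH]1`: 10 nM

In an in vitro functional assay on cells for agonist activity at Bombesin receptor subtype-3 (Mus musculus), read by luminescence and calcium flux (a lower number here means that less compound is needed, a higher number that more compound is needed for the effect), compound 3 stands second highest of the three numbers. Its nearest neighbour is compound 1, and the step of a 1.3-fold higher number from compound 1 to compound 3 (0.10 log units; within the scatter) lies within the scatter, so no order can be read between those two. The step of a 2.2-fold lower number from compound 2 to compound 3 (0.34 log units; beyond the scatter) lies beyond the scatter and is modest in size.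

Compound 4 `O=C(O)c1ccccc1-c1ccc(CCc2ncc(Cc3cccc(Cl)c3)[nH]2)cc1` has not been measured. Its change from compound 3 is 3-chlorophenyl in place of isobutyl on a saturated chain carbon bound to an aromatic carbon. Among the compounds with values here, two measured steps bear on it: a 2.8-fold higher number from compound 1 to compound 2 (0.44 log units; beyond the scatter) and a 2.2-fold lower number from compound 2 to compound 3 (0.34 log units; beyond the scatter), both showing that a chlorophenyl group at this place gives a modestly higher number than a saturated group. Within the data shown here, the reverse of the second of these suggests a modest rise for compound 4, though no measured compound carries a 3-chlorophenyl group, so the size is uncertain. The expected step is a 2.0-fold higher number from compound 3 to compound 4 (0.30 log units; within the scatter). Compound 4 is therefore estimated at 20 nM, with a range from 8 nM to 50 nM.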

Compound 4, half-maximal effective concentration: 31 nM
Estimate against measurement, compound 4: 1.6-fold (0.19 log units) below; the measured number falls inside the stated range.
By their numbers in this assay, from the lowest: compounds 1 and 3 (each within the scatter of the next); then compounds 2 and 4 (each within the scatter of the next).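

In this assay, the chlorine's place on the ring makes no readable difference: a 1.4-fold higher number from compound 2 to compound 4 (0.15 log units; within the scatter) gives no order between the 3-chlorophenyl and 2-chlorophenyl groups. Compound 4 instead joins compound 2 in standing apart from the saturated groups, with a 3.1-fold higher number from compound 3 to compound 4 (0.49 log units; beyond the scatter) against isobutyl and a 3.9-fold higher number from compound 1 to compound 4 (0.59 log units; beyond the scatter) against cyclopentyl, both beyond the scatter and modest in size. Among these four compounds, both chlorophenyl groups therefore give higher numbers than both saturated groups, with no compound going against that pattern, and no evidence is available to explain the difference.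

The compounds shown leave open whether the chlorine matters at all, since an unsubstituted phenyl group does not appear among them. They also do not show how an amine or a longer chain at this place would read.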